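Chalcone series: removing the chloro from compound 1

The source may hold more compounds than are shown below. What is called first, only, known or untested is meant among the compounds shown, and "the series" means these compounds.

For the measured compounds named here, compound 1 `CNC(=O)c1cc(Oc2ccc(C(=O)/C=C/c3ccc(F)cc3Cl)cc2)ccn1` is the weaker of the two compounds measured so far. In a functional assay on A549 cells (Homo sapiens) for cytotoxicity, read by MTT assay, with a stated time of 72 h (a lower number here means a stronger inhibitor, a higher number a weaker inhibitor), compound 1 gives 21100 nM, the highest of the two numbers; the nearest is compound 2 `CNC(=O)c1cc(Oc2ccc(C(=O)/C=C/c3cc(OC)c(OC)c(OC)c3)cc2)ccn1`, which in this assay gives 9500 nM, a gap beyond the usual scatter. Going by the values given here, no pair of measured compounds differs in one place, so no step in this assay is yet known for any single change. Compound 3 `CNC(=O)c1cc(Oc2ccc(C(=O)/C=C/c3ccc(F)cc3)cc2)ccn1` differs from compound 1 in one place: hydrogen in place of chloro on an aromatic carbon. Cut one bond further out, 2-chloro-4-fluorophenyl becomes 4-fluorophenyl. Among the compounds with values here, with no measured step of this kind to lean on, the expected step is a 1.2-fold higher number from compound 1 to compound 3 (0.07 log units; within the scatter), of modest size and in no clear direction beyond the scatter. Compound 3 is therefore expected to give about 25000 nM in this assay, within an estimated range from 8000 nM to 70000 nM.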

Compound 3, half-maximal inhibitory concentration: 18600 nM
Compound 3: middle estimate off by 1.3-fold (0.13 log units), on the high side; low and high end bracket the measured number.
By their numbers in this assay, from the lowest: compounds 2, 3 and 1 (each within the scatter of the next, the first and the last beyond it).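

In this assay, for the compounds shown here, hydrogen in place of chloro on an aromatic carbon gives a 1.1-fold lower number from compound 1 to compound 3 (0.05 log units; within the scatter) and is the only single-place step available. At this position, ortho to a large group and meta to a fluoro group, the chloro makes no readable difference: 2-chloro-4-fluorophenyl and 4-fluorophenyl cannot be told apart in this read-out. No measured data are available to explain this flat step.

Still open, going by these compounds, is whether any group on this aromatic carbon can move the number beyond the scatter, for example an amine or a carboxylic acid in place of the hydrogen of compound 3. Also open, on these data alone, is what the fluoro group contributes, which a step from compound 3 to an analogue carrying a nitrile at that place would begin to show.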